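The source may report more compounds than this note shows. Statements on the series, on what has been measured and on what is new or still open speak of the compounds shown alone.

Working notes on the series. Compound 1 `O=C(Nc1ccc(-n2ncc3c(C(F)(F)F)cccc32)cc1)Nc1ccc(Cl)c(C(F)(F)F)c1`, compound 2 `O=C(Nc1ccc(-n2ncc3c(Cl)cccc32)cc1)Nc1ccc(Cl)c(C(F)(F)F)c1` and compound 3 `Cc1cccc2c1cnn2-c1ccc(NC(=O)Nc2ccc(Cl)c(C(F)(F)F)c2)cc1` share one core and differ only in a single group on an aromatic carbon within the fused system. In a functional assay on HT-29 cells (Homo sapiens) for cytotoxicity, read by MTT assay, with a stated time of 72 h (a higher number here means a weaker inhibitor, a lower number a stronger inhibitor), compound 1 gives 2900 nM, compound 2 gives 4600 nM and compound 3 gives 32000 nM. Compound 2 stands second highest of the three numbers: the step of a 1.6-fold higher number from compound 1 to compound 2 (0.20 log units; within the scatter) lies within the scatter, whereas a 7.0-fold higher number from compound 2 to compound 3 (0.84 log units; beyond the scatter) and an 11-fold higher number from compound 1 to compound 3 (1.04 log units; beyond the scatter) lie beyond it.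

Compound 4 `COc1cccc2c1cnn2-c1ccc(NC(=O)Nc2ccc(Cl)c(C(F)(F)F)c2)cc1` is not yet measured. It differs from compound 2 by methoxy in place of chloro on an aromatic carbon. The step of a 7.0-fold higher number from compound 2 to compound 3 (0.84 log units; beyond the scatter) bears on this most directly, since it also removes the chloro from the same aromatic carbon and replaces it with a small group without halogen, and an 11-fold higher number from compound 1 to compound 3 (1.04 log units; beyond the scatter) points the same way. For the measured compounds named here, no measured step carries a methoxy on that carbon, so the expectation rests on the methyl analogy and is uncertain. A rise in the number beyond the scatter is expected for compound 4, of a size estimated as a 3.3-fold higher number from compound 2 to compound 4 (0.51 log units; beyond the scatter). Compound 4 is therefore expected to give 15000 nM in this assay, with a range from 5000 nM to 45000 nM.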

Compound 4, half-maximal inhibitory concentration: > 32000 nM
Compound 4 was reported as a limit; the forecaster's own chance of this, stated with the estimate: 5%; middle value at least 2.1-fold (0.32 log units) from the limit.
By their numbers in this assay, from the lowest: compounds 1 and 2 (each within the scatter of the next); then compound 3.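

In this assay compound 4 gives > 32000 nM, which is a limit of the assay and not a number. Until now only methyl had been seen to replace a halogen-bearing group on this aromatic carbon, and methoxy now gives a second such case, with the steps of an at least 6.9-fold higher number from compound 2 to compound 4 (0.84 log units; beyond the scatter) and an at least 11-fold higher number from compound 1 to compound 4 (1.04 log units; beyond the scatter), so across the four compounds shown the numbers beyond the scatter from the chloro and trifluoromethyl compounds go with both groups without halogen, and no compound shown goes against this. The comparison of methoxy with methyl on this carbon, the step of a number no lower from compound 3 to compound 4 (the limit leaves the size open), cannot be read for size, because the new value is reported only as a limit: the limit of > 32000 nM in this assay, at which 1 of the 4 values shown sits.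

The compounds shown leave open whether a fluoro, a bromo or a nitrile on this aromatic carbon would stay with chloro and trifluoromethyl or move with methyl and methoxy. They also leave open what an amine, a hydroxyl or a longer chain such as ethoxy would do here, and whether the link between halogen and a lower number holds beyond these four compounds.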